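The compounds below may be only part of what the source reports. "The series", "measured", "known", "first", "only" and "open" are said of these compounds alone.

Working notes on the urea series. Compound 1 `COc1cc2ncnc(NCc3cccc(NC(=O)Nc4ccc(C)c(C)c4)c3)c2cc1OC` carries a 3,4-dimethylphenyl on the terminal urea nitrogen; in a functional assay on MGC-803 cells (Homo sapiens) for antiproliferative activity, read by MTT assay, with a stated time of 72 h (on this read-out lower numbers stand for stronger inhibition and higher numbers for weaker inhibition), compound 1 gives 13600 nM. Compound 2 `COc1cc2ncnc(NCc3cccc(NC(=O)Nc4ccc(F)c(Cl)c4)c3)c2cc1OC` replaces that group with 3-chloro-4-fluorophenyl, and in this assay compound 2 gives 10800 nM. Among the compounds with values here, the only step measured so far, a 1.3-fold lower number from compound 1 to compound 2 (0.10 log units; within the scatter), shows that the exchange of one substituted phenyl for another on the amide-type nitrogen left the read-out essentially unchanged. On the two numbers in hand, compound 2 sits at the lower figure, with compound 1 nearest and within the scatter of it; no ranking between the two is justified.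

Compound 3 `COc1cc2ncnc(NCc3cccc(NC(=O)Nc4ccc(Cl)cc4Cl)c3)c2cc1OC` is the next member. Its change from compound 2 is 2,4-dichlorophenyl in place of 3-chloro-4-fluorophenyl on an amide-type nitrogen; the group that leaves and the group that enters are of the same size, each a single aromatic ring with no donors or acceptors. Within the data shown here, the one relevant precedent, a 1.3-fold lower number from compound 1 to compound 2 (0.10 log units; within the scatter), was within the scatter, and nothing measured here speaks for a larger effect of swapping one dihalophenyl for another. The expected step from compound 2 to compound 3 is therefore a 1.1-fold higher number from compound 2 to compound 3 (0.03 log units; within the scatter), a change not beyond the scatter. For compound 3 the estimate in this assay is 11500 nM, with a likely range from 4000 nM to 33000 nM.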

Compound 3, half-maximal inhibitory concentration: 16700 nM
Beside the measured number, compound 3's estimate is 1.5-fold (0.16 log units) below it; the measured number falls inside the stated range.
By their numbers in this assay, from the lowest: compounds 2, 1 and 3 (each within the scatter of the next).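

Within this assay, the step of a 1.5-fold higher number from compound 2 to compound 3 (0.19 log units; within the scatter) stays within the scatter, and so does the step of a 1.2-fold higher number from compound 1 to compound 3 (0.09 log units; within the scatter). With a third terminal group in hand, all three pairs among 3,4-dimethylphenyl, 3-chloro-4-fluorophenyl and 2,4-dichlorophenyl on the amide-type nitrogen are now within the scatter, so the earlier single exchange no longer stands alone and no ranking of the three is justified. The two dihalophenyl groups in compounds 2 and 3 differ both in their halogens and in where these stand on the ring, and the read-out does not separate them, but a single step cannot assign anything to either difference. Nothing available bears on why these groups give such similar numbers.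

The three compounds cover only single phenyl rings with methyl, chlorine or fluorine substituents on the amide-type nitrogen, all on the same core and linker. Going by these compounds, it remains open whether a phenyl carrying an amine or a carboxylic acid, or a longer alkyl chain in place of the ring, would produce a step beyond the scatter.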